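Hydrazone step on a series without measured potency

This account rests on a few compounds, and the source may have more. Where it says the series, first, only, none or still open, it means among the compounds named here.

In a functional assay, read by spectrophotometry, with a stated time of 1 h (on this read-out higher numbers stand for weaker inhibition and lower numbers for stronger inhibition), compound 1 `O=c1cc(/C=N\O)c2c(OCc3ccccc3)cc(OCc3ccccc3)cc2o1` gives "not active" (no number reported), so it offers no number to start from. Compound 3 `O=c1cc(-c2nc3ccccc3[nH]2)c2ccc(OCc3ccccc3)cc2o1` likewise gives "not active" (no number reported). Compound 2 `O=c1cc(/C=N\Nc2ccc([N+](=O)[O-])cc2)c2ccc(OCc3ccccc3)cc2o1` reports only a limit, > 2000000 nM. Compound 4 `O=c1cc(/C=N\Nc2ccccc2)c2c(OCc3ccccc3)cc(OCc3ccccc3)cc2o1` remains unmeasured. The step anilino in place of hydroxy on a double-bonded nitrogen puts anilino in place of hydroxy on a double-bonded nitrogen. Going by the values given here, no measured step gives a size to build on. In this assay only a small move toward stronger inhibition is expected, or none, and weak inhibition is expected to remain, judging from compound 2 with its limit of > 2000000 nM. For compound 4 the estimated value is 500000 nM, with an expected range of 50000 nM to 2000000 nM.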

Compound 4, half-maximal inhibitory concentration: 401000 nM
Beside the measured number, compound 4's estimate is 1.2-fold (0.10 log units) above it; measured number inside the range.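

In this assay, going by these compounds alone, compound 4 gives 401000 nM and compound 1 gives "not active" (no number reported), so no step between these two compounds can be read. As far as these compounds go, the size of any change from putting anilino in place of hydroxy remains open.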